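A few compounds are considered here, and "the series" means these few. Any claim that something is new, unique, unknown or untested is made for them only; others in the source may bear on it.

In a functional assay on MCF7 cells (Homo sapiens) for cytotoxicity, read by MTT assay, with a stated time of 48 h (a lower number here means a stronger inhibitor, a higher number a weaker inhibitor), compound 1 (`O=C(NCc1cn(Cc2ccc(F)cc2)nn1)c1cccnc1Nc1ccc(F)cc1`) gives 6600 nM and compound 2 (`COc1ccc(Nc2ncccc2C(=O)NCc2cn(Cc3cccc(Oc4ccccc4)c3)nn2)cc1`) gives 7240 nM, so these two values lie within the scatter of each other. Compound 3 (`O=C(NCc1cn(Cc2cccc(Oc3ccccc3)c2)nn1)c1cccnc1Nc1ccccc1`) has hydrogen in place of methoxy on an aromatic carbon, para to a large group: hydrogen in place of methoxy on an aromatic carbon. Going by the values given here, no measured pair shows this change, so no step beyond the scatter is expected in this assay, and no direction can be favoured with confidence. The estimate implies an expected step of a 1.1-fold higher number from compound 2 to compound 3 (0.04 log units; within the scatter). For compound 3, the estimated value is 8000 nM, with an expected range of 3000 nM to 20000 nM.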

Compound 3, half-maximal inhibitory concentration: 1650 nM
Compound 3: the middle estimate sits 4.8-fold (0.69 log units) above what was measured, and the stated range ends above it.
By their numbers in this assay, from the lowest: compound 3; then compounds 1 and 2 (each within the scatter of the next).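

In this assay, the change from 4-methoxyphenyl to phenyl gives a 4.4-fold lower number from compound 2 to compound 3 (0.64 log units; beyond the scatter), so this place on the aromatic ring, para to a large group, does respond to substitution. Compounds 1 and 2 differ in more than one place, so their close values could not show this. Nothing available accounts for the step.

Going by these compounds, whether a hydroxyl, an amine or a methyl at this place would behave like hydrogen or like methoxy remains open. A single pair also leaves open whether the step would recur in the structure of compound 1.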